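The source may report more compounds than this note shows. Statements on the series, on what has been measured and on what is new or still open speak of the compounds shown alone.

In a functional assay on B16-F1 cells (Mus musculus) for antiproliferative activity, read by MTT assay, with a stated time of 72 h (a lower number here means a stronger inhibitor, a higher number a weaker inhibitor), compound 1 (`C/C=C1/[C@H](O[C@@H]2O[C@H](CO)[C@@H](O)[C@H](O)[C@H]2O)OC=C(C(=O)OC)[C@H]1CC(=O)OCCCCCCCCCCCCCCC`) gives 1500 nM, while compound 2 (`C/C=C1/[C@H](O[C@@H]2O[C@H](CO)[C@@H](O)[C@H](O)[C@H]2O)OC=C(C(=O)OC)[C@H]1CC(=O)OCCC1CCCCC1`) gives 5040 nM, the higher of the two numbers, with a gap beyond the scatter. Compound 3 (`C/C=C1/[C@H](O[C@@H]2O[C@H](CO)[C@@H](O)[C@H](O)[C@H]2O)OC=C(C(=O)OC)[C@H]1CC(=O)OCCC(C)C`) departs from compound 2 in one place: isopropyl in place of cyclohexyl on a saturated chain carbon, two bonds along the chain from an oxygen next to a carbonyl group. Among the compounds with values here, no measured pair shows this change on its own. With only two esters to go on, the larger one, in compound 1 at 1500 nM, is the stronger, so a moderate rise in the number is expected, meaning weaker inhibition. The estimated change is a 1.8-fold higher number from compound 2 to compound 3 (0.25 log units; within the scatter). For compound 3 the expected value is 9000 nM, with a likely range from 3500 nM to 25000 nM.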

Compound 3, half-maximal inhibitory concentration: 39100 nM
Compound 3: middle estimate off by 4.3-fold (0.64 log units), on the low side, and the stated range ends below it.
By their numbers in this assay, from the lowest: compound 1; then compound 2; then compound 3.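

In this assay, isopropyl in place of cyclohexyl on a saturated chain carbon, two bonds along the chain from an oxygen next to a carbonyl group, gives a 7.8-fold higher number from compound 2 to compound 3 (0.89 log units; beyond the scatter) and so weakens inhibition. Within the data shown here, this is the first change at this position that can be read on its own, and it shows that the position does not tolerate this swap without loss. Nothing at hand explains the loss. Going by these compounds, what a phenyl, cyclopentyl or straight hexyl group would do at this place stays open, as does whether the ring itself or the carbon count lies behind the step.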